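Hydroxymethyl in place of formyl on the chain

The source may report more compounds than this note shows. Statements on the series, on what has been measured and on what is new or still open speak of the compounds shown alone.

Compound 1 `Cn1c(Cc2nn(C)c(=O)c3ccccc23)nnc1SCC(=O)Nc1ccc(Cl)cc1Cl` gives 21100 nM in an assay on 32D cells for inhibition of interleukin-15 (Mus musculus), read by resazurin assay, with stated times of 30 min and 2.5 days, in the presence of a further agent that is not named here; on this read-out higher numbers stand for weaker inhibition and lower numbers for stronger inhibition. Compound 3 `Cn1c(Cc2nn(CCC=O)c(=O)c3ccccc23)nnc1SCC(=O)Nc1ccc(Cl)cc1Cl` gives 30000 nM in this assay, the higher of the two numbers shown, with compound 1 nearest at a 1.4-fold higher number from compound 1 to compound 3 (0.15 log units; within the scatter). Compound 2 `Cn1c(Cc2nn(CCC3OCCO3)c(=O)c3ccccc23)nnc1SCC(=O)Nc1ccc(Cl)cc1Cl` reaches the limit > 30000 nM in this assay. That is the limit of > 30000 nM in this assay, at which 1 of the 3 values shown sits. The step of a number no higher from compound 2 to compound 3 (the limit leaves the size open) cannot be sized. Compound 4 `Cn1c(Cc2nn(CCCO)c(=O)c3ccccc23)nnc1SCC(=O)Nc1ccc(Cl)cc1Cl` differs from compound 3 by hydroxymethyl in place of formyl on a saturated chain carbon, two bonds along the chain from an aromatic nitrogen. Among the measured compounds shown here, the steps that bear on this change, a 1.4-fold higher number from compound 1 to compound 3 (0.15 log units; within the scatter) and a number no higher from compound 2 to compound 3 (the limit leaves the size open), show nothing beyond the scatter, so no step beyond the scatter is expected in this assay. Compound 4 is therefore estimated at 30000 nM, between 12000 nM and 60000 nM. That estimate means an expected step of no change at the digits printed from compound 3 to compound 4 (within the scatter).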

Compound 4, half-maximal inhibitory concentration: > 30000 nM
Compound 4: no number, only a limit; the forecaster's own chance of this, stated with the estimate: 45%; the middle value sits exactly at the limit.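

Compound 4 gives only a limit, > 30000 nM, in this assay. Hydroxymethyl in place of formyl, which brings a hydrogen-bond donor onto the chain, shows no readable gain: the data give an at least 1.4-fold higher number from compound 1 to compound 4 (0.15 log units; that floor lies within the scatter), and the step from compound 2 to compound 4 cannot be read. The 3-hydroxypropyl chain of compound 4 thus stands at the same limit as compound 2 in this assay: the limit of > 30000 nM in this assay, at which 2 of the 4 values shown sit.

For hydroxymethyl in place of formyl itself, the data give a number no lower from compound 3 to compound 4 (the limit leaves the size open). As far as these compounds go, whether a 3-aminopropyl chain, a carboxylic acid at the chain end or a longer chain would give a number clear of this limit stays open.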